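The source may report more compounds than this note shows. Statements on the series, on what has been measured and on what is new or still open speak of the compounds shown alone.

Compound 2 `c1ccc(Cc2nnc(-c3c[nH]c4ccccc34)o2)cc1` in a functional assay on MDA-MB-231 cells (Homo sapiens) for cytotoxicity, read by MTT assay (a lower number here means a stronger inhibitor, a higher number a weaker inhibitor), gives only a limit of the assay, > 1000000 nM. Compound 1 `c1ccc(-c2nnc(-c3c[nH]c4ccccc34)o2)cc1` in this assay likewise gives only a limit, > 1000000 nM. For the measured compounds named here, the single measured step, a step that the two limits leave unreadable from compound 1 to compound 2, is therefore of unknown size, since both values sit at the limit of > 1000000 nM in this assay, at which 2 of the 2 values shown sit. Compound 3 `c1ccc2c(-c3nnc(-c4ccncc4)o3)c[nH]c2c1` differs from compound 2 by pyridin-4-yl in place of benzyl on an aromatic carbon. Going by the values given here, no measured step of readable size bears on this change, so nothing beyond the scatter is expected in either direction, and the most likely outcome is again a limit. Compound 3 is therefore expected at 1000000 nM, between 200000 nM and 5000000 nM, which means an expected step of a number no higher from compound 2 to compound 3 (the limit leaves the size open).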

Compound 3, half-maximal inhibitory concentration: > 1000000 nM
Compound 3 gave a limit, no number (the forecaster's own chance of this, stated with the estimate: 80%); the middle value lies on the limit itself.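

Compound 1, compound 2 and compound 3 all give only limits, so no step among them can be read: the limit of > 1000000 nM in this assay, at which 3 of the 3 values shown sit.

How strongly any of these compounds acts in this assay, and whether the phenyl, benzyl or pyridin-4-yl group changes that, stays open.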